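Trimethoxyphenyl in place of hydroxymethoxyphenyl: compound 3

A few compounds are considered here, and "the series" means these few. Any claim that something is new, unique, unknown or untested is made for them only; others in the source may bear on it.

Compound 1 `CN(C)CCn1cnnc1-c1cc(Oc2ccc(NC(=O)N/N=C/c3cccc(O)c3)cc2F)ccn1` carries a 3-hydroxyphenyl on the carbon with a double bond to nitrogen. In a functional assay on U-87MG ATCC cells (Homo sapiens) for cytotoxicity, read by MTT assay, with a stated time of 72 h (on this read-out higher numbers stand for weaker inhibition and lower numbers for stronger inhibition), compound 1 gives only a limit, > 100000 nM. Compound 2 `COc1cc(/C=N/NC(=O)Nc2ccc(Oc3ccnc(-c4nncn4CCN(C)C)c3)c(F)c2)ccc1O` carries a 4-hydroxy-3-methoxyphenyl on the carbon with a double bond to nitrogen. In this assay compound 2 likewise returns a limit, > 100000 nM. The step that the two limits leave unreadable from compound 1 to compound 2 is of unreadable size. Going by the values given here, compound 2 thus stands at the limit of this assay, as does the one other value shown, and the evidence here is the limit of > 100000 nM in this assay, at which 2 of the 2 values shown sit, so no ordering within the pair can be drawn.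

Compound 3 `COc1cc(/C=N/NC(=O)Nc2ccc(Oc3ccnc(-c4nncn4CCN(C)C)c3)c(F)c2)cc(OC)c1OC` differs from compound 2 as follows: 3,4,5-trimethoxyphenyl in place of 4-hydroxy-3-methoxyphenyl on a carbon with a double bond to nitrogen. Among the compounds with values here, the only measured step, from compound 1 to compound 2, also exchanged the aryl on this carbon and left both ends at the limit; nothing measured shows that a change at this carbon brings the read-out into the readable range. For compound 3 the expectation is accordingly another limit or a value near it, a step of a number no higher from compound 2 to compound 3 (the limit leaves the size open) of no readable size. Compound 3 is estimated at 100000 nM in this assay, with a range from 30000 nM to 300000 nM.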

Compound 3, half-maximal inhibitory concentration: 22500 nM
Compound 3: the middle estimate sits 4.4-fold (0.65 log units) above what was measured; the measured number lies below the stated range.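

Exchanging 4-hydroxy-3-methoxyphenyl for 3,4,5-trimethoxyphenyl on the carbon with a double bond to nitrogen gives, in this assay, an at least 4.4-fold lower number from compound 2 to compound 3 (0.64 log units; beyond the scatter), and exchanging 3-hydroxyphenyl for the same group gives an at least 4.4-fold lower number from compound 1 to compound 3 (0.64 log units; beyond the scatter). Going by these compounds, the aryl at this position can therefore bring the read-out into the readable range, which the earlier pair could not show, as the step between its two members cannot be read; the two new steps give only a lower bound on their size, and the true gap stays open: the limit of > 100000 nM in this assay, at which 2 of the 3 values shown sit. Of the three aryl groups, only the 3,4,5-trimethoxyphenyl of compound 3 carries no hydroxy group, and it is also the one with the most methoxy groups.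

The compounds shown do not separate the loss of the hydroxy group from the gain of a further methoxy group, since both occur in the single change to compound 3. On these data alone, a 3,4-dimethoxyphenyl on this carbon would bear on that question, and whether a value well below that of compound 3 is reachable at this position remains open.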